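The source may report more compounds than this note shows. Statements on the series, on what has been measured and on what is new or still open speak of the compounds shown alone.

Measured in a functional assay on MCF7 cells (Homo sapiens) for antiproliferative activity, read by MTT assay, with a stated time of 48 h; a lower number here means a stronger inhibitor, a higher number a weaker inhibitor:
compound 1 `COc1cc(CNC(=O)CCCCCCC(C)C)ccc1OCCCCOc1ccc(C(N)=S)cc1`: 4990 nM
compound 2 `COc1cc(CNC(=O)CCCC/C=C/C(C)C)ccc1OCCCCOc1ccc(C(N)=S)cc1`: 49800 nM
compound 3 `COc1cc(CNC(=O)CCCC/C=C/C(C)C)ccc1OCCCCCOc1ccc(C(N)=S)cc1`: 17200 nM

Of these three, compound 2 gives the highest number, 49800 nM, which makes it the weakest of the set. Compound 3 lies nearest to it and compound 1 furthest.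

Compound 4 `COc1cc(CNC(=O)CCCC/C=C/C(C)C)ccc1OCCCCOc1ccc(-c2cc(=S)ss2)cc1` keeps all of compound 2 except one group. The change is a group of 6 heavy atoms (3 carbon, 3 sulfur; one five-membered aromatic ring with 2 hetero atoms) in place of a group of 3 heavy atoms (1 carbon, 1 nitrogen, 1 sulfur; no ring), on an aromatic carbon, on an aromatic carbon of a six-membered aromatic ring of carbon only, para to a large group. Within the data shown here, no measured compound differs at this place, so the two measured steps bear on it only indirectly. The exchange on the amide-bearing chain gave a 10-fold higher number from compound 1 to compound 2 (1.00 log units; beyond the scatter), and the exchange on the chain between the two ether oxygens gave a 2.9-fold lower number from compound 2 to compound 3 (0.46 log units; beyond the scatter). Both are modest, and they suggest what one structural change can do in this small series. A step of similar size is therefore expected in this assay, though one within the scatter cannot be ruled out. The direction is not fixed by the data, but a lower number seems more likely, since compound 2 stands at the top at 49800 nM. The expected step is a 2.5-fold lower number from compound 2 to compound 4 (0.40 log units; beyond the scatter). Compound 4 is estimated at 20000 nM, with an expected range of 5000 nM to 70000 nM.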

Compound 4, half-maximal inhibitory concentration: 36400 nM
Compound 4: the middle estimate sits 1.8-fold (0.26 log units) below what was measured, within the range that was stated.
By their numbers in this assay, from the lowest: compound 1; then compound 3; then compounds 4 and 2 (each within the scatter of the next).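

Among these compounds, this is the first change at the aromatic carbon para to a large group, and in this assay the exchange of the group of 3 heavy atoms, with no ring, for the group of 6 heavy atoms, with one five-membered aromatic ring with 2 hetero atoms, gave a 1.4-fold lower number from compound 2 to compound 4 (0.14 log units; within the scatter). So a much larger group, carrying 0 hydrogen-bond donors where the group it replaced carried 1, left the number within the scatter, whereas each of the two chain exchanges in the series moved it beyond the scatter. Nothing available explains why this exchange left the number within the scatter.

The compounds shown leave open whether the same exchange would also stay within the scatter on the background of compound 1, which gives 4990 nM with its saturated chain, or on that of compound 3, with its longer chain linking the two ether oxygens. They also leave open how a carboxylic acid, an amine or a nitrile would behave at this aromatic carbon in this assay.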